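The source may report more compounds than this note shows. Statements on the series, on what has been measured and on what is new or still open speak of the compounds shown alone.

In a functional assay on MOLT-4 cells (Homo sapiens) for inhibition (on this read-out lower numbers stand for stronger inhibition and higher numbers for weaker inhibition), compound 1 (`O=C1CCCCC/C1=C\c1ccccc1`) gives 215000 nM. For compound 2 (`Cc1ccc(/C=C2\CCCCCC2=O)cc1`) the assay reports only a limit, > 500000 nM, so its position is bounded and not fixed by a number. Going by the values given here, the one measured step is an at least 2.3-fold higher number from compound 1 to compound 2 (0.36 log units; beyond the scatter), with methyl in place of hydrogen on an aromatic carbon. Compound 3 (`CN(C)c1ccc(/C=C2\CCCCCC2=O)cc1`) alters that same group: dimethylamino in place of methyl on an aromatic carbon, with dimethylamino in place of methyl on an aromatic carbon, para to a group of 9 heavy atoms. Among the compounds with values here, only this one step bears on the change, and it does not involve dimethylamino, so the guidance is weak. A modest move toward stronger inhibition in this assay is nonetheless expected, back toward the level of compound 1 at 215000 nM. The expected change is an at least 2.0-fold lower number from compound 2 to compound 3 (0.30 log units; that floor lies within the scatter). For compound 3 the estimated value is 250000 nM, with an expected range from 70000 nM to 500000 nM.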

Compound 3, half-maximal inhibitory concentration: 57400 nM
Beside the measured number, compound 3's estimate is 4.4-fold (0.64 log units) above it; measured number outside the range, below it.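

On this aromatic carbon, para to a group of 9 heavy atoms, the substituent can strengthen inhibition as well as weaken it in this assay: dimethylamino in place of hydrogen gives a 3.7-fold lower number from compound 1 to compound 3 (0.57 log units; beyond the scatter), the opposite direction to the methyl step. In place of methyl, dimethylamino gives an at least 8.7-fold lower number from compound 2 to compound 3 (0.94 log units; beyond the scatter). That step is only a floor, as compound 2 is known solely by a limit of the assay: the limit of > 500000 nM in this assay, at which 1 of the 3 values shown sits.

On these data alone, whether a primary amine, a methoxy group or a diethylamino group on this carbon would follow dimethylamino remains open. So does what dimethylamino would do elsewhere on the aromatic ring, and whether the shift seen here would hold on a changed core.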